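The source may hold more compounds than are shown below. What is called first, only, known or untested is meant among the compounds shown, and "the series" means these compounds.

Three compounds have been measured in an assay on HEK293 cells for inhibition of N-acylethanolamine-hydrolyzing acid amidase (Homo sapiens), read by fluorescence, with stated times of 10 min and 50 min; a lower number here means a stronger inhibitor, a higher number a weaker inhibitor:

compound 1, `C[C@H]1[C@H](NC(=O)OCCCCC2CCCCC2)C(=O)N1Oc1ccccc1`, gives 23 nM
compound 2, `C[C@H]1[C@H](NC(=O)OCCCCC2CCCCC2)C(=O)N1Oc1ccc(C(F)(F)F)cc1`, gives 31 nM
compound 3, `C[C@H]1[C@H](NC(=O)OCCCCC2CCCCC2)C(=O)N1Oc1ccc([N+](=O)[O-])cc1`, gives 17 nM

All three share one core and differ only in the substituent on the aromatic ring that is joined to the core through oxygen. Compound 3 shows the lowest of the three numbers, but the gaps are small: the step of a 1.4-fold lower number from compound 1 to compound 3 (0.13 log units; within the scatter) and the step of a 1.8-fold lower number from compound 2 to compound 3 (0.26 log units; within the scatter) both lie within the scatter, so the three cannot be put in order. The step of a 1.3-fold higher number from compound 1 to compound 2 (0.13 log units; within the scatter) is within the scatter as well.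

Compound 4, `C[C@H]1[C@H](NC(=O)OCCCCC2CCCCC2)C(=O)N1Oc1ccc(Oc2ccccc2)cc1`, is compound 3 with one change: phenoxy in place of nitro on an aromatic carbon. For the measured compounds named here, the steps that bear on this are the three at the same position, from hydrogen to trifluoromethyl, from hydrogen to nitro and from trifluoromethyl to nitro, and none of them moved the number beyond the scatter. Phenoxy brings in more atoms than any of those groups, so it is untested ground, yet on what is known no step beyond the scatter is expected in this assay. The expected step is a 1.5-fold higher number from compound 3 to compound 4 (0.17 log units; within the scatter). Compound 4 is therefore estimated at about 25 nM, between 8 nM and 80 nM.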

Compound 4, half-maximal inhibitory concentration: 48 nM
Beside the measured number, compound 4's estimate is 1.9-fold (0.28 log units) below it, and the stated range covers the measured number.
By their numbers in this assay, from the lowest: compounds 3, 1, 2 and 4 (each within the scatter of the next, the first and the last beyond it).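

For the compounds shown here, at this position hydrogen, trifluoromethyl and nitro could not be told apart, but phenoxy gives the first steps beyond the scatter in this assay: a 2.8-fold higher number from compound 3 to compound 4 (0.45 log units; beyond the scatter) and a 2.1-fold higher number from compound 1 to compound 4 (0.32 log units; beyond the scatter), both modest. The group is still not set apart from all the others, as a 1.5-fold higher number from compound 2 to compound 4 (0.19 log units; within the scatter) stays within the scatter, so even a substituent that adds a six-membered aromatic ring shifts the number only slightly. Nothing measured here offers a reason for these steps.

Still open, as far as these compounds go, is whether the added aromatic ring or its linking oxygen goes with the higher number, which a phenyl or a methoxy group on the same carbon could help separate. Also open, from the compounds shown here alone, is what an amine or a carboxylic acid would do at this position.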